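The source may report more compounds than this note shows. Statements on the series, on what has been measured and on what is new or still open speak of the compounds shown alone.

Compound 1, `Cc1ccc(OCc2cn(Cc3ccc([N+](=O)[O-])cc3)nn2)cc1`: in an ADME assay on A549 cells (Homo sapiens) for inhibition, read by MTT assay, with a stated time of 48 h (a lower number here means a stronger inhibitor of growth, a higher number a weaker inhibitor of growth), compound 1 gives > 100 ug/mL, which is a limit of the assay.
Compound 2, `Cc1ccc(OCc2cn(Cc3ccc(Cl)cc3)nn2)cc1`: in this assay compound 2 gives > 100 ug/mL, also a limit.
Compound 3, `Cc1cc(OCc2cn(Cc3ccc([N+](=O)[O-])cc3)nn2)ccc1Cl`: in this assay compound 3 gives > 100 ug/mL, again a limit.

All three values sit at the same limit, (the limit of > 100 ug/mL in this assay, at which 3 of the 3 values shown sit). The step that the two limits leave unreadable from compound 1 to compound 2 carries the change (chloro in place of nitro on an aromatic carbon). The two cores differ by 4-chloro-3-methylphenyl in place of 4-methylphenyl on an oxygen on a saturated carbon, and the step that the two limits leave unreadable from compound 1 to compound 3 is likewise unreadable. Compound 4, `Cc1cc(OCc2cn(Cc3ccc(Cl)cc3)nn2)ccc1Cl`, is not yet measured; it differs from compound 3 by chloro in place of nitro on an aromatic carbon, the same change, made at a place described in the same words. The step from compound 3 to compound 4 is expected to be a step that the limit leaves unreadable from compound 3 to compound 4, resting on the matching step that the two limits leave unreadable from compound 1 to compound 2, which left both ends at the limit (the limit of > 100 ug/mL in this assay, at which 3 of the 3 values shown sit). Compound 4 is therefore estimated at 150 ug/mL, most likely reported only as a limit, within 60 ug/mL to 500 ug/mL.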

Compound 4, concentration for 50% growth inhibition: > 100 ug/mL
Compound 4: only a limit was reported; the forecaster's own chance of this, stated with the estimate: 85%; the middle value does not contradict the limit.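

Compound 3 and compound 4 both stand at a limit rather than a number, so no step between them can be read: the limit of > 100 ug/mL in this assay, at which 4 of the 4 values shown sit.

The compounds shown leave open how strongly any of them inhibits growth in this assay, and whether chloro in place of nitro changes that.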